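Replacing the Last Methoxy with Fluoro on the Styryl Ring

A few compounds are considered here, and "the series" means these few. Any claim that something is new, unique, unknown or untested is made for them only; others in the source may bear on it.

Among the measured compounds shown here, compound 2 `COc1cc(/C=C/C(=O)Nc2cc(C(=O)c3cc(OC)c(OC)c(OC)c3)ccc2OC)ccc1F` gives 13600 nM in a functional assay on HeLa cells (Homo sapiens) for cytotoxicity, read by MTT assay, with a stated time of 72 h (on this read-out lower numbers stand for stronger inhibition and higher numbers for weaker inhibition), the highest of the two numbers so far; its nearest neighbour, compound 1 `COc1ccc(C(=O)c2cc(OC)c(OC)c(OC)c2)cc1NC(=O)/C=C/c1ccc(OC)c(OC)c1`, gives 7800 nM, and the step of a 1.7-fold higher number from compound 1 to compound 2 (0.24 log units; within the scatter) was within the scatter. Compound 3 `COc1ccc(C(=O)c2cc(OC)c(OC)c(OC)c2)cc1NC(=O)/C=C/c1ccc(F)c(F)c1` differs from compound 2 by fluoro in place of methoxy on an aromatic carbon. For the measured compounds named here, the only measured step bearing on this change is a 1.7-fold higher number from compound 1 to compound 2 (0.24 log units; within the scatter), which was within the scatter, so no step beyond the scatter is expected, a 1.2-fold higher number from compound 2 to compound 3 (0.07 log units; within the scatter). Compound 3 is therefore estimated at 16000 nM, with a range from 7000 nM to 36000 nM.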

Compound 3, half-maximal inhibitory concentration: 8100 nM
Beside the measured number, compound 3's estimate is 2.0-fold (0.30 log units) above it, within the range that was stated.
By their numbers in this assay, from the lowest: compounds 1, 3 and 2 (each within the scatter of the next).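

In this assay, the step of a 1.7-fold lower number from compound 2 to compound 3 (0.23 log units; within the scatter) stays within the scatter, so fluoro in place of methoxy at this position, ortho to a fluoro group, gives no readable change. With both groups exchanged, a 1.0-fold higher number from compound 1 to compound 3 (0.02 log units; within the scatter) also stays within the scatter, so 3,4-difluorophenyl and 3,4-dimethoxyphenyl cannot be told apart here. No evidence is available on what lies behind these results.

Going by these compounds, all three compounds carry small groups on this ring, so it remains open whether an amine, a hydroxyl or a carboxylic acid there would produce a step beyond the scatter.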